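This account rests on a few compounds, and the source may have more. Where it says the series, first, only, none or still open, it means among the compounds named here.

In a functional assay on MCF7 cells (Homo sapiens) for antiproliferative activity (a higher number here means a weaker inhibitor, a lower number a stronger inhibitor), compound 1 `O=[N+]([O-])c1ccc(S(=O)(=O)N2CC(n3cnc4ncnc(O)c43)OCc3ccccc32)cc1` reaches only the assay limit, > 100000 nM, which is a limit and not a number, so compound 1 stands at the weak end of what has been measured; this is recorded as the limit of > 100000 nM in this assay, at which 1 of the 3 values shown sits. Compound 2 `O=[N+]([O-])c1ccc(S(=O)(=O)N2CC(n3cnc4ncnc(Sc5ccccc5)c43)OCc3ccccc32)cc1` gives 860 nM in this assay, and compound 3 `O=[N+]([O-])c1ccccc1S(=O)(=O)N1CC(n2cnc3ncnc(O)c32)OCc2ccccc21` gives 19700 nM. Compound 4 `O=[N+]([O-])c1ccc(S(=O)(=O)N2CC(n3cnc4c(Cl)ncnc43)OCc3ccccc32)cc1` differs from compound 1 by a group of 10 heavy atoms (5 carbon, 4 nitrogen, 1 chlorine; one five-membered aromatic ring with 2 hetero atoms, one six-membered aromatic ring with 2 hetero atoms) in place of a group of 10 heavy atoms (5 carbon, 4 nitrogen, 1 oxygen; one five-membered aromatic ring with 2 hetero atoms, one six-membered aromatic ring with 2 hetero atoms), on a saturated ring carbon: in short, a chlorine takes the place of the hydroxy on the shared core. Of the two measured steps, the replacement of the hydroxy by phenylsulfanyl bears most directly on this change, and it was large: an at least 110-fold lower number from compound 1 to compound 2 (2.06 log units; beyond the scatter). The other step, an at least 5.0-fold lower number from compound 1 to compound 3 (0.70 log units; beyond the scatter), concerns the nitrophenyl part and says less about the present change. Since compound 2 shows that removing the hydroxy brought an at least 110-fold lower number from compound 1 to compound 2 (2.06 log units; beyond the scatter), a clear gain is expected for compound 4 as well, though the chlorine is smaller than phenylsulfanyl, so the expected step is an at least 20-fold lower number from compound 1 to compound 4 (1.30 log units; beyond the scatter). Compound 4 is therefore estimated at 5000 nM, within 800 nM to 30000 nM.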

Compound 4, half-maximal inhibitory concentration: 2730 nM
For compound 4 the middle estimate is 1.8-fold (0.26 log units) above the measured one; low and high end bracket the measured number.
By their numbers in this assay, from the lowest: compound 2; then compound 4; then compound 3. At a limit, above all of these: compound 1.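

A chlorine in place of the hydroxy on the shared core also gives a large step, an at least 36-fold lower number from compound 1 to compound 4 (1.56 log units; beyond the scatter), so in this assay a large step at this position does not depend on the added benzene ring of phenylsulfanyl. Within the data shown here, with the two replacements side by side, compound 2 gives 860 nM and compound 4 gives 2730 nM, which is the first view of how the group replacing the hydroxy matters here. The true size of the step remains unknown because compound 1 stands at a limit, not a number: the limit of > 100000 nM in this assay, at which 1 of the 4 values shown sits.

The compounds shown leave open how an amine, a methoxy group or a bromine would compare with chlorine at this position. They also leave open whether the 2-nitrophenyl group of compound 3 would add to the chlorine step.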